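Halogen swap on the aromatic ring: bromo, chloro, fluoro

A few compounds are considered here, and "the series" means these few. Any claim that something is new, unique, unknown or untested is made for them only; others in the source may bear on it.

Measured so far:
compound 1 `O=C1NC(=S)/C(=C/c2ccccc2Br)S1` 21.2%
compound 2 `O=C1NC(=S)/C(=C/c2ccccc2Cl)S1` 21.2%

Compound 2 `O=C1NC(=S)/C(=C/c2ccccc2Cl)S1` stands level with compound 1 `O=C1NC(=S)/C(=C/c2ccccc2Br)S1` in a functional assay on HEp-2 cells (Homo sapiens) for cytotoxicity, read by MTT assay, with a stated time of 72 h, tested at 10 ug/mL; on this read-out higher numbers stand for more inhibition of growth at the one concentration tested and lower numbers for less inhibition of growth; the step of no change at the digits printed from compound 1 to compound 2 (within the scatter) lies within the scatter. Compound 3 `O=C1NC(=S)/C(=C/c2ccccc2F)S1` is not yet measured. It differs from compound 2 by fluoro in place of chloro on an aromatic carbon. Within the data shown here, the only step that bears on this change is the one from compound 1 to compound 2, which was flat; on that basis no step beyond the scatter is expected, and the expected step of a number 0.2 percentage points lower from compound 2 to compound 3 (within the scatter) is small. Compound 3 is therefore estimated at 21% in this assay, within 8% to 36%.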

Compound 3, percent growth inhibition at one concentration: 11.2%
Beside the measured number, compound 3's estimate is 9.8 percentage points above it; the measured number falls inside the stated range.
By their numbers in this assay, from the lowest: compounds 3, 1 and 2 (each within the scatter of the next).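

In this assay, fluoro on this aromatic carbon gives a number 10 percentage points lower from compound 2 to compound 3 (within the scatter) and a number 10 percentage points lower from compound 1 to compound 3 (within the scatter). Unlike chloro and bromo, which print the same number, fluoro separates the printed values, but both steps stay within the scatter, so no effect of the choice among these three halogens at this place is shown. Nothing available bears on a cause for these numbers.

Open, as far as these compounds go, is whether a non-halogen group here, such as an amine, a methoxy group or a carboxylic acid, would give a step beyond the scatter. Also open, from the compounds shown here alone, is how these halogens read on other carbons of the aromatic ring.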